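The source may hold more compounds than are shown below. What is called first, only, known or untested is meant among the compounds shown, and "the series" means these compounds.

Measured so far in an assay for inhibition of platelet-activating factor acetylhydrolase (Rattus norvegicus), in plasma, with stated times of 30 min and 10 min, tested at 50 nM; on this read-out higher numbers stand for more inhibition at the one concentration tested (going by the name of the read-out) and lower numbers for less inhibition:
compound 1 `CC(=O)Nc1ccc(S(=O)(=O)Nc2ccc(Oc3ccc(Cl)c(C(F)(F)F)c3)c(C#N)c2)cc1` gives 32%.
compound 2 `N#Cc1cc(NS(=O)(=O)c2ccc(NC(=O)N3CCOCC3)cc2)ccc1Oc1ccc(Cl)c(C(F)(F)F)c1` gives 27%.
compound 3 `N#Cc1cc(NS(=O)(=O)c2ccc(N3CCNCC3)cc2)ccc1Oc1ccc(Cl)c(C(F)(F)F)c1` gives 31%.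

All three share one core and differ only in the group carried on the outer aromatic ring of the sulfonamide side. Compound 3 sits among numbers that do not separate: a number 1 percentage points lower from compound 1 to compound 3 (within the scatter) and a number 4 percentage points higher from compound 2 to compound 3 (within the scatter).

Compound 4 `CC(=O)N(C)c1ccc(S(=O)(=O)Nc2ccc(Oc3ccc(Cl)c(C(F)(F)F)c3)c(C#N)c2)cc1` is the next step from compound 3: acetyl(methyl)amino in place of piperazin-1-yl on an aromatic carbon. Among the measured compounds shown here, the group that enters is close to the acetamido of compound 1, so the step that bears most on it is the one from compound 1 to compound 3, which was within the scatter, as was the step from compound 2 to compound 3. The expectation is therefore no change at the digits printed from compound 3 to compound 4 (within the scatter), nothing beyond the scatter. Compound 4 is estimated at 31%, between 18% and 44%.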

Compound 4, a percentage reported as inhibition, at one concentration (the size of the read-out at that concentration, not a potency): 15%
Beside the measured number, compound 4's estimate is 16 percentage points above it; the measured number lies below the stated range.
By their numbers in this assay, from the lowest: compound 4; then compounds 2, 3 and 1 (each within the scatter of the next).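

In this assay, the group on this aromatic carbon turns out to matter: a single methyl in place of hydrogen on the amide-type nitrogen gives a number 17 percentage points lower from compound 1 to compound 4 (beyond the scatter). The other two steps agree, with a number 16 percentage points lower from compound 3 to compound 4 (beyond the scatter) and a number 12 percentage points lower from compound 2 to compound 4 (beyond the scatter), so acetyl(methyl)amino stands apart from three groups whose numbers did not separate. Nothing measured here explains this difference.

From the compounds shown here alone, it remains open whether only methyl on this nitrogen has this effect, or whether a larger group such as ethyl would do the same. A plain amino group on this aromatic carbon is also an open case.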